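Extending the ethynyl group of compound 1

The source may hold more compounds than are shown below. What is called first, only, known or untested is meant among the compounds shown, and "the series" means these compounds.

- compound 1 `C#Cc1cccc(N/N=N/c2ccc(C(=N)N)cc2)c1`: 16800 nM
- compound 2 `N=C(N)c1ccc(/N=N/Nc2ccccc2C#Cc2ccccc2)cc1`: 8100 nM
- compound 3 `C#Cc1ccc(N/N=N/c2ccc(C(=N)N)cc2)cc1`: 11800 nM

These three values come from a functional assay on OVCAR-3 cells (Homo sapiens) for antiproliferative activity, read by WST assay, with a stated time of 72 h; on this read-out lower numbers stand for stronger inhibition of growth and higher numbers for weaker inhibition of growth. Compound 1 gives 16800 nM in this measure. Compound 3, at 11800 nM, lies within the scatter of compound 1, while compound 2, at 8100 nM, lies lower and beyond the scatter.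

The next compound to be tested is compound 4 `N=C(N)c1ccc(/N=N/Nc2cccc(C#Cc3ccc(F)cc3)c2)cc1`. It differs from compound 1 by one change: 4-fluorophenyl in place of hydrogen on a triple-bonded carbon. In other words, the ethynyl becomes 2-(4-fluorophenyl)ethynyl. Among the compounds with values here, no pair of measured compounds shows this change on its own, so any expectation is indirect. The closest guide is compound 2, which also has a ring on its triple-bonded carbon and gives 8100 nM. That single comparison is thin support, but it points to a moderate move toward stronger inhibition of growth, slightly beyond the scatter. The estimated step is a 2.8-fold lower number from compound 1 to compound 4 (0.45 log units; beyond the scatter). For compound 4 the estimated value is 6000 nM, with an expected range from 2000 nM to 16000 nM.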

Compound 4, concentration for 50% growth inhibition: 5000 nM
Compound 4: the middle estimate sits 1.2-fold (0.08 log units) above what was measured; the range from low to high includes it.
By their numbers in this assay, from the lowest: compounds 4, 2, 3 and 1 (each within the scatter of the next, the first and the last beyond it).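

In this assay, within the data shown here, placing 4-fluorophenyl in place of hydrogen on the triple-bonded carbon gives a 3.4-fold lower number from compound 1 to compound 4 (0.53 log units; beyond the scatter), a modest step and the first direct reading of any change at this carbon. The earlier compounds shown here offered no such pair, whereas this one shows that a ring can be carried on this carbon with stronger, not weaker, inhibition of growth. Nothing given here accounts for the size of this step.

The compounds shown leave open whether the fluorine contributes to the step or whether a plain phenyl on the same carbon would do as much. Also open, as far as these compounds go, is what an amine or a carboxylic acid on that ring, or a simple alkyl chain in place of the ring, would do to growth inhibition.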